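A few compounds are considered here, and "the series" means these few. Any claim that something is new, unique, unknown or untested is made for them only; others in the source may bear on it.

Compound 1, `COc1cc(-c2nn(-c3cccc(NC(=O)c4cccc(C(F)(F)F)c4)c3)cc2-c2ccncc2)ccc1Cl`, was tested in a functional assay on HOP-92 cells (Homo sapiens) for inhibition, read by sulforhodamine B assay, with a stated time of 48 h; on this read-out higher numbers stand for weaker inhibition of growth and lower numbers for stronger inhibition of growth. In this assay compound 1 gives 555 nM. Within the data shown here, compound 2, `O=C(Nc1cccc(-n2cc(-c3ccncc3)c(-c3ccc(Cl)c(O)c3)n2)c1)Nc1cc(C(F)(F)F)cc(C(F)(F)F)c1`, is the only other compound with a result here; in this assay compound 2 gives 344 nM, and the gap between these two numbers lies within the usual scatter of repeated measurements, so neither can be called the stronger inhibitor. Compound 3, `COc1cc(-c2nn(-c3cccc(NC(=O)Nc4ccc(Cl)c(C(F)(F)F)c4)c3)cc2-c2ccncc2)ccc1Cl`, shares the core of compound 1 and differs from it in one place: (4-chloro-3-(trifluoromethyl)phenyl)amino in place of 3-(trifluoromethyl)phenyl on a carbonyl carbon. Among the measured compounds shown here, no measured pair shows this exact change, so the step can only be judged from the fact that compound 2, which also carries an amino group on its carbonyl carbon, gives 344 nM in this assay. The step from compound 1 to compound 3 is therefore expected to be small, a 1.4-fold lower number from compound 1 to compound 3 (0.14 log units; within the scatter), and not clearly beyond the scatter. Compound 3 is estimated to give 400 nM in this assay, with a likely range from 150 nM to 1100 nM.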

Compound 3, concentration for 50% growth inhibition: 499 nM
Compound 3: the middle estimate sits 1.2-fold (0.10 log units) below what was measured; the range from low to high includes it.
By their numbers in this assay, from the lowest: compounds 2, 3 and 1 (each within the scatter of the next).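

Among these compounds, compounds 1 and 3 form the first pair that differs in one place, and swapping 3-(trifluoromethyl)phenyl for (4-chloro-3-(trifluoromethyl)phenyl)amino on the carbonyl carbon gives a 1.1-fold lower number from compound 1 to compound 3 (0.05 log units; within the scatter) in this assay. This place on the shared core therefore accepts the larger group, with its extra amino nitrogen and chlorine, without a measurable shift in growth inhibition. Nothing measured here explains this result.

The amino nitrogen and the chlorine enter together, so the effect of each alone cannot be read from this pair, and either effect could be hidden by the other. As far as these compounds go, it also remains open whether this place would accept a group without an aromatic ring, such as a simple methyl or a morpholine.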